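Replacing the hydroxy group of compound 3

The compounds below may be only part of what the source reports. "The series", "measured", "known", "first", "only" and "open" are said of these compounds alone.

- compound 1 `O=C1COc2ccccc2N1CCCn1cc(-c2ccccc2)nn1`: 4900 nM
- compound 2 `COc1ccc(-c2cn(CCCN3C(=O)COc4ccccc43)nn2)cc1`: 41500 nM
- compound 3 `O=C1COc2ccccc2N1CCCn1cc(CO)nn1`: 5700 nM

All three values come from a functional assay on MDA-MB-231 cells (Homo sapiens) for antiproliferative activity, read by sulforhodamine B assay, with a stated time of 48 h; a lower number here means a stronger inhibitor of growth, a higher number a weaker inhibitor of growth. Compound 3 stands level with compound 1, as the step of a 1.2-fold higher number from compound 1 to compound 3 (0.07 log units; within the scatter) shows, and clearly under compound 2, with a 7.3-fold lower number from compound 2 to compound 3 (0.86 log units; beyond the scatter). Compound 4 `O=C1COc2ccccc2N1CCCn1cc(CCCCl)nn1` carries this change: 2-chloroethyl in place of hydroxy on a saturated chain carbon bound to an aromatic carbon. Hydroxymethyl thus becomes 3-chloropropyl. Within the data shown here, no measured step makes this exact swap. The closest guide is the exchange of phenyl for hydroxymethyl, a 1.2-fold higher number from compound 1 to compound 3 (0.07 log units; within the scatter), which left the number within the scatter. Yet adding methoxy gave an 8.5-fold higher number from compound 1 to compound 2 (0.93 log units; beyond the scatter), so a small edit can matter, and the range must stay wide. The expected step is a 1.1-fold higher number from compound 3 to compound 4 (0.06 log units; within the scatter), which means no change beyond the scatter. The estimate for compound 4 is 6500 nM, with an expected range of 2200 nM to 20000 nM.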

Compound 4, concentration for 50% growth inhibition: 6400 nM
The estimate for compound 4 lay 1.0-fold (0.01 log units) above the measured number, within the range that was stated.
By their numbers in this assay, from the lowest: compounds 1, 3 and 4 (each within the scatter of the next); then compound 2.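

In this assay the change of hydroxy to 2-chloroethyl on a saturated chain carbon bound to an aromatic carbon moves the number only within the scatter (a 1.1-fold higher number from compound 3 to compound 4 (0.05 log units; within the scatter)), so this place tolerates a group with no hydrogen-bond donor or acceptor. The 3-chloropropyl group also stands level with phenyl (a 1.3-fold higher number from compound 1 to compound 4 (0.12 log units; within the scatter)), while 4-methoxyphenyl remains apart (a 6.5-fold lower number from compound 2 to compound 4 (0.81 log units; beyond the scatter)). Nothing measured here explains why these groups give such similar numbers. On these data alone, whether an amine, a carboxylic acid or a longer chain in place of 3-chloropropyl would keep the number level remains open.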